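The compounds below may be only part of what the source reports. "The series", "measured", "known", "first", "only" and "open" are said of these compounds alone.

Working notes on the series. In an ADME assay on L6 cells (Rattus norvegicus) for cytotoxicity (a lower number here means a stronger inhibitor, a higher number a weaker inhibitor), compound 1 (`Cc1nc(-c2ccccn2)nc(N)c1Cl`) gives 85300 nM and compound 2 (`Cc1nc(-c2ccccn2)nc(N(C)C)c1Cl`) gives 115000 nM as its value. The step between them (a 1.3-fold higher number from compound 1 to compound 2 (0.13 log units; within the scatter)) lies within the scatter, so compound 2 stands level with compound 1 on these numbers. Compound 3 (`CCN(CC)c1nc(-c2ccccn2)nc(C)c1Cl`) has not yet been measured. It carries diethylamino in place of dimethylamino on an aromatic carbon, next to the ring nitrogen and ortho to a chloro group (diethylamino in place of dimethylamino on an aromatic carbon). For the measured compounds named here, only one measured step bears on this change: the replacement at the same place in compound 2 (a 1.3-fold higher number from compound 1 to compound 2 (0.13 log units; within the scatter)), which stayed within the scatter. One step is thin evidence, but it gives no reason to expect a real shift. The estimated step is a 1.2-fold lower number from compound 2 to compound 3 (0.08 log units; within the scatter) and nothing beyond the scatter is expected in this assay here. Compound 3 is expected at 95000 nM with an estimated range of 45000 nM to 190000 nM for the coming measurement.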

Compound 3, half-maximal inhibitory concentration: 148000 nM
Estimate against measurement, compound 3: 1.6-fold (0.19 log units) below; the measured number falls inside the stated range.
By their numbers in this assay, from the lowest: compounds 1, 2 and 3 (each within the scatter of the next).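

Diethylamino, with 5 heavy atoms, in place of dimethylamino, with 3, gives a 1.3-fold higher number from compound 2 to compound 3 (0.11 log units; within the scatter) in this assay, so this position on the aromatic carbon, next to the ring nitrogen and ortho to a chloro group, tolerates the larger dialkylamino group in this assay without a real shift. The wider change, diethylamino in place of amino, gives a 1.7-fold higher number from compound 1 to compound 3 (0.24 log units; within the scatter), so even the largest change shown at this position stays inside the noise and the three compounds cannot be ranked here. No measured evidence bears on why these numbers stay level.

As far as these compounds go, it remains open whether a cyclic amine such as morpholine, a longer chain such as dipropylamino, or a carboxylic acid at this position would give a step beyond the scatter. From the compounds shown here alone, whether the same level reading holds when the chloro group or the methyl group is replaced also remains open.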